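The source may report more compounds than this note shows. Statements on the series, on what has been measured and on what is new or still open speak of the compounds shown alone.

Compound 2 `COc1cc2nnc(C(N)=O)c(Nc3ccc(C)cc3F)c2cc1N1CCN(S(C)(=O)=O)CC1` stands highest of the three numbers in an ADME assay on a cell-free system (plasma, Rattus norvegicus) for protein binding (on this read-out lower numbers stand for a smaller free fraction and higher numbers for a larger free fraction), where compound 2 gives 0.091. Compound 3 `COc1cc2nnc(C(N)=O)c(Nc3ccc(C)cc3F)c2cc1N1CCN(C)CC1` gives 0.063, and compound 1 `COc1cc2nnc(C(N)=O)c(Nc3ccc(C)cc3F)c2cc1N1CCC(OC)CC1` gives 0.012. The two steps leaving compound 1 were a 7.6-fold higher number from compound 1 to compound 2 (0.88 log units; beyond the scatter) and a 5.3-fold higher number from compound 1 to compound 3 (0.72 log units; beyond the scatter). Compound 4 `COc1cc2nnc(C(N)=O)c(Nc3ccc(C)cc3F)c2cc1N1CCN(C(C)C)CC1` differs from compound 2 by isopropyl in place of methylsulfonyl on an amine nitrogen in a ring. The step that bears on this most is a 1.4-fold lower number from compound 2 to compound 3 (0.16 log units; within the scatter), where methylsulfonyl likewise gave way to an alkyl group on the same ring nitrogen and the number stayed within the scatter. Compound 4 is therefore expected to land close to compound 2, with no step beyond the scatter. The expected step is a 1.4-fold lower number from compound 2 to compound 4 (0.15 log units; within the scatter). Compound 4 is estimated at 0.065, with a likely range from 0.03 to 0.13.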

Compound 4, unbound fraction: 0.066
Estimate against measurement, compound 4: 1.0-fold (0.01 log units) below; measured number inside the range.
By their numbers in this assay, from the lowest: compound 1; then compounds 3, 4 and 2 (each within the scatter of the next).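

In this assay, the group on this ring nitrogen can now be methylsulfonyl, methyl or isopropyl with no step beyond the scatter: a 1.4-fold lower number from compound 2 to compound 4 (0.14 log units; within the scatter), and a 1.0-fold higher number from compound 3 to compound 4 (0.02 log units; within the scatter). The clear gap remains the one at the whole ring substituent, where 4-isopropylpiperazin-1-yl joins the other two piperazine groups apart from 4-methoxypiperidin-1-yl, with a 5.5-fold higher number from compound 1 to compound 4 (0.74 log units; beyond the scatter). No measurement here explains why these nitrogen groups read alike. Still open, on these data alone, is whether this insensitivity would hold with only hydrogen on that nitrogen, or with a longer chain ending in a carboxylic acid.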